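Trifluoromethylsulfonyl to Acetyl: Expected Cytotoxicity Outcome

This account rests on a few compounds, and the source may have more. Where it says the series, first, only, none or still open, it means among the compounds named here.

Compound 1 `Cc1cc(C#N)cc(C)c1Oc1nc(Nc2ccc(C#N)cc2)ncc1/C=C/C(=O)NC1CCN(S(C)(=O)=O)CC1` and compound 2 `Cc1cc(C#N)cc(C)c1Oc1nc(Nc2ccc(C#N)cc2)ncc1/C=C/C(=O)N1CCN(S(=O)(=O)C(F)(F)F)CC1` share a common core and differ only in the group attached at the amide end of the chain. In an ADME assay on TZM cells (Homo sapiens) for cytotoxicity, with a stated time of 1 days (on this read-out higher numbers stand for lower toxicity in this test and lower numbers for higher toxicity in this test), compound 1 gives > 175 nM, which is a limit of the assay rather than a measured number. In this assay compound 2 gives > 164 nM, again a limit rather than a number. Compound 2 therefore stands at the limit of > 164 nM in this assay, at which 1 of the 2 values shown sits. Compound 1 stands at the limit of > 175 nM in this assay, at which 1 of the 2 values shown sits.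

Compound 3 `CC(=O)N1CCN(C(=O)/C=C/c2cnc(Nc3ccc(C#N)cc3)nc2Oc2c(C)cc(C#N)cc2C)CC1` has yet to be tested in this assay. It arises from compound 2 by the change (acetyl in place of (trifluoromethyl)sulfonyl on an amine nitrogen in a ring). Because both measured compounds sit at limits, no step size between them can be read, and nothing measured speaks for a move in either direction. The step from compound 2 to compound 3 is expected to be a step that the limit leaves unreadable from compound 2 to compound 3, not beyond the scatter. Compound 3 is expected to give 200 nM, within a range from 100 nM to 450 nM.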

Compound 3, half-maximal cytotoxic concentration: > 192 nM
Compound 3 gave a limit, no number; the forecaster's own chance of this, stated with the estimate: 80%; the middle value is on the limit's open side.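

Within the data shown here, compound 1, compound 2 and compound 3 all give only limits in this assay, not numbers, and no step from compound 1 or compound 2 to compound 3 can be read. Going by these compounds, how far each true value lies past its limit remains open, as does any real difference among the three compounds.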